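This account rests on a few compounds, and the source may have more. Where it says the series, first, only, none or still open, it means among the compounds named here.

In a functional assay on DU-145 cells (Homo sapiens) for cytotoxicity, read by CCK-8 assay (a lower number here means a stronger inhibitor, a higher number a weaker inhibitor), compound 1 (`Oc1cccc(-c2cc(-c3ccsc3)cc(-c3ccccc3O)n2)c1`) gives > 50000 nM as a limit of the assay and not a number. Compound 2 (`Oc1ccc(-c2cc(-c3ccsc3)cc(-c3ccccc3O)n2)cc1`) gives > 50000 nM, again only a limit. So compound 2 stands at the limit of > 50000 nM in this assay, at which 2 of the 3 values shown sit, and its true value is unknown. Compound 3 (`Oc1ccc(-c2cc(-c3ccsc3)cc(-c3cccc(O)c3)n2)cc1`) gives a real number, 2230 nM, in the same test.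

Compound 4 (`Oc1ccc(-c2cc(-c3cccnc3)cc(-c3ccccc3O)n2)cc1`) differs from compound 2 in one place, opposite the ring nitrogen of the shared core, where pyridin-3-yl stands in place of thiophen-3-yl (pyridin-3-yl in place of thiophen-3-yl on an aromatic carbon).

Going by the values given here, no measured step touches this group, so the evidence is indirect. The steps that can be read all concern the hydroxyphenyl groups. Putting 3-hydroxyphenyl in place of 2-hydroxyphenyl gives an at least 22-fold lower number from compound 2 to compound 3 (1.35 log units; beyond the scatter), and putting 4-hydroxyphenyl in place of 2-hydroxyphenyl gives an at least 22-fold lower number from compound 1 to compound 3 (1.35 log units; beyond the scatter), both large. The remaining comparison is a step that the two limits leave unreadable from compound 1 to compound 2. Among these three compounds, only the one without a 2-hydroxyphenyl group gives a number, and compound 4 keeps that group.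

The expected result is therefore an at least 1.2-fold lower number from compound 2 to compound 4 (0.09 log units; that floor lies within the scatter), with no clear gain in strength expected beyond the scatter. For compound 4 the estimated value is 40000 nM, with an expected range from 10000 nM to 80000 nM.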

Compound 4, half-maximal inhibitory concentration: > 50000 nM
Compound 4 gave a limit, no number; the forecaster's own chance of this, stated with the estimate: 60%; middle value at least 1.2-fold (0.09 log units) from the limit.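

In this assay compound 4 gives > 50000 nM, a limit of the assay and not a number. Compound 2 also gives only a limit, so the step between compound 2 and compound 4 cannot be read. The compounds shown leave open whether pyridin-3-yl in place of thiophen-3-yl changes the value at all.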